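Aryloxyacetamide series: isopropyl for fluoro on the aryl ring

The source may hold more compounds than are shown below. What is called first, only, known or untested is meant among the compounds shown, and "the series" means these compounds.

Measured compounds:
compound 1, `CCN(Cc1cccs1)C(=O)COc1ccc(F)cc1`: 422 nM
compound 2, `CCN(Cc1c[nH]nn1)C(=O)COc1ccc(C)cc1`: 31100 nM
compound 3, `Cc1ccc(OCC(=O)N(Cc2cccs2)C2COC2)cc1`: 23000 nM

Of the compounds shown here, three have been measured in an assay on HEK293 cells for agonist activity at transient receptor potential cation channel subfamily M member 8 (Homo sapiens), read by fluorescence and calcium flux, with a stated time of 15 min; a higher number here means that more compound is needed for the effect, a lower number that less compound is needed. Compound 1 gives the lowest number of the three in this assay, with 422 nM. Compound 3 comes nearest, and its value of 23000 nM lies beyond the scatter from compound 1. Compound 2 is furthest, at 31100 nM, also beyond the scatter. Both compound 2 and compound 3 differ from compound 1 in more than one place, so what the two gaps show cannot be assigned to any single change.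

Compound 4, `CCN(Cc1cccs1)C(=O)COc1ccc(C(C)C)cc1`, has not been measured. It differs from compound 1 in one place: isopropyl in place of fluoro on an aromatic carbon. Going by the values given here, no pair of measured compounds shows this change, so the size of the step is open. The isopropyl group is the larger of the two, and the change is expected to cost little, with the step from compound 1 to compound 4 estimated as a 1.2-fold lower number from compound 1 to compound 4 (0.08 log units; within the scatter), most likely within the scatter. Compound 4 is expected to give about 350 nM in this assay, within a range from 70 nM to 1800 nM.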

Compound 4, half-maximal effective concentration: 397 nM
Estimate against measurement, compound 4: 1.1-fold (0.05 log units) below; the measured number falls inside the stated range.
By their numbers in this assay, from the lowest: compounds 4 and 1 (each within the scatter of the next); then compounds 3 and 2 (each within the scatter of the next).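

In this assay, going by these compounds alone, the first single-place step, isopropyl in place of fluoro on an aromatic carbon gives a 1.1-fold lower number from compound 1 to compound 4 (0.03 log units; within the scatter) at this position para to a large group. Here 3 heavy atoms replace 1 heavy atom without a step beyond the scatter, so at this position the number does not separate the two groups. Nothing measured accounts for this result.

Within the data shown here, still open is whether an amine, a carboxylic acid or a longer chain at this position would also leave the number within the scatter of compound 1, since fluoro and isopropyl are the only two groups compared here. The gaps to compound 2 and compound 3 cannot be read as steps, as each of these differs from compound 1 in more than one place.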